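The source may hold more compounds than are shown below. What is called first, only, known or untested is meant among the compounds shown, and "the series" means these compounds.

Going by the values given here, compound 1 `Fc1cccc(-c2nc(Nc3ccccc3)c3cc(F)ccc3n2)c1` is the only member of this small set with a definite number. In a functional assay on MCF7 cells (Homo sapiens) for cytotoxicity, read by MTT assay, with a stated time of 48 h (on this read-out higher numbers stand for weaker inhibition and lower numbers for stronger inhibition), compound 1 gives 49700 nM. Compound 2 `Oc1ccccc1Nc1nc(-c2cccc(F)c2)nc2ccc(F)cc12` carries a hydroxy in place of a hydrogen on an aromatic carbon, and compound 3 `Nc1ccc(Nc2nc(-c3cccc(F)c3)nc3ccc(F)cc23)cc1` carries an amino in place of a hydrogen on an aromatic carbon. In this assay compound 2 reaches only a limit of the measurement, > 50000 nM. In this assay compound 3 likewise reaches only a limit, > 50000 nM. The step of a number no lower from compound 1 to compound 2 (the limit leaves the size open) and the step of a number no lower from compound 1 to compound 3 (the limit leaves the size open) therefore have no readable size, and the step that the two limits leave unreadable from compound 2 to compound 3 is unreadable as well, because both of those values sit at the limit of > 50000 nM in this assay, at which 2 of the 3 values shown sit. Compound 4 `Nc1ccccc1Nc1nc(-c2cccc(F)c2)nc2ccc(F)cc12` differs from compound 1 by amino in place of hydrogen on an aromatic carbon. The two steps that bear on this change both ended at the limit, so a number no lower than that of compound 1 is expected, and quite possibly only a limit again. Compound 4 is expected to give 60000 nM, within 25000 nM to 150000 nM. That estimate means a step of a 1.2-fold higher number from compound 1 to compound 4 (0.08 log units; within the scatter), expected to stay within the scatter.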

Compound 4, half-maximal inhibitory concentration: > 50000 nM
Compound 4 gave a limit, no number; the forecaster's own chance of this, stated with the estimate: 65%; the middle value does not contradict the limit.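

The change from phenyl to 2-aminophenyl gives a number no lower from compound 1 to compound 4 (the limit leaves the size open) in this assay, so an amino group ortho to a large group now joins the 2-hydroxyphenyl of compound 2 and the 4-aminophenyl of compound 3 in giving no definite number. Compound 4 reaches only a limit of the measurement, > 50000 nM. The steps among compound 2, compound 3 and compound 4 cannot be read, so neither moving the amino group nor exchanging it for hydroxy can be given a size, because all three compounds end at the same point: the limit of > 50000 nM in this assay, at which 3 of the 4 values shown sit.

On these data alone, how far past the limit these three compounds lie stays open. Also open, as far as these compounds go, is whether a smaller or different group on this ring, such as a methoxy, a chlorine or a carboxylic acid, would give a definite number in this assay.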